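Amide swap at the cytotoxicity end of a chloroquinoline series

A few compounds are considered here, and "the series" means these few. Any claim that something is new, unique, unknown or untested is made for them only; others in the source may bear on it.

Compound 1 `CCCCCC(=O)NCCCN1CCN(CCCNc2ccnc3cc(Cl)ccc23)CC1`: "not determined" (no result reported).
Compound 2 `O=C(CCCc1c[nH]c2ccccc12)NCCCN1CCN(CCCNc2ccnc3cc(Cl)ccc23)CC1`: 6500 nM.
Compound 3 `CC(C)=CC(=O)NCCCN1CCN(CCCNc2ccnc3cc(Cl)ccc23)CC1`: 30000 nM.
Compound 4 `O=C(NCCCN1CCN(CCCNc2ccnc3cc(Cl)ccc23)CC1)c1cc(Cl)cc(Cl)c1`: to be measured.

All four compounds share one core and differ only in the group on the amide carbonyl. In an ADME assay on L6 cells (Rattus norvegicus) for cytotoxicity (on this read-out lower numbers stand for stronger inhibition and higher numbers for weaker inhibition), compound 3 gives 30000 nM, the highest of the two numbers available, while compound 2 gives 6500 nM. Among the measured compounds shown here, the single recorded step, a 4.6-fold higher number from compound 2 to compound 3 (0.66 log units; beyond the scatter), shows that exchanging a chain carrying an aromatic ring for the small alkenyl group moved the number up.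

Compound 4 reverses that direction of change: 3,5-dichlorophenyl in place of 2-methylprop-1-en-1-yl on a carbonyl carbon. For the measured compounds named here, no measured step involves a dichlorophenyl group, so the only guide is the step from compound 2 to compound 3, which brought an aromatic ring in a chain. Going by the values given here, on that basis the expected step is a 3.8-fold lower number from compound 3 to compound 4 (0.57 log units; beyond the scatter), a lower number in this assay for compound 4 than for compound 3, of modest size comparable to the one recorded step. Compound 4 is therefore estimated at 8000 nM, within a range of 2500 nM to 25000 nM.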

Compound 4, half-maximal inhibitory concentration: 3000 nM
For compound 4 the middle estimate is 2.7-fold (0.43 log units) above the measured one; measured number inside the range.
By their numbers in this assay, from the lowest: compound 4; then compound 2; then compound 3.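

In this assay the change to 3,5-dichlorophenyl on the carbonyl carbon gives a 10-fold lower number from compound 3 to compound 4 (1.00 log units; beyond the scatter), so an aromatic ring does not need a connecting chain to bring the number below that of the small alkenyl group. Replacing the indole-bearing chain gives a 2.2-fold lower number from compound 2 to compound 4 (0.34 log units; beyond the scatter), which places compound 4 lowest of the three compounds with numbers, with both of its steps beyond the scatter. Nothing measured here explains this order.

On these data alone, what an unsubstituted phenyl or a 3-chlorophenyl would give on the same carbonyl carbon remains open, so the share of the two chlorines in these steps cannot be told. Compound 1 gives "not determined" (no result reported), so its steps to the other compounds cannot be read.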